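Ester variation at the prodrug carbonyl: compound 4

This account rests on a few compounds, and the source may have more. Where it says the series, first, only, none or still open, it means among the compounds named here.

Working notes on a series built on the shared core of compound 1 `C[C@@H](O)[C@H]1C(=O)N2C(C(=O)OCOC(=O)C(C)(C)C)=C(S[C@@H]3CN[C@H](C(=O)Nc4cccc(C(=O)O)c4)C3)[C@H](C)[C@H]12`. In an ADME assay for metabolic stability, read by LC-MS, with a stated time of 3 h, at pH 6.5, tested at 50 uM (a lower number here means that less of the compound is left, a higher number that more of the compound is left), compound 1 gives > 95%, which is a limit of the assay rather than a number. Compound 2 `C[C@@H](O)[C@H]1C(=O)N2C(C(=O)OCC(F)(F)F)=C(S[C@@H]3CN[C@H](C(=O)Nc4cccc(C(=O)O)c4)C3)[C@H](C)[C@H]12` also returns a limit in this assay, > 95%. Compound 3 `CCOC(=O)OCOC(=O)C1=C(S[C@@H]2CN[C@H](C(=O)Nc3cccc(C(=O)O)c3)C2)[C@H](C)[C@@H]2[C@@H]([C@@H](C)O)C(=O)N12` likewise sits at a limit in this assay, > 95%. Compound 3 thus stands where every measured member stands, at the limit of > 95% in this assay, at which 3 of the 3 values shown sit, and the steps a step that the two limits leave unreadable from compound 1 to compound 2, a step that the two limits leave unreadable from compound 1 to compound 3 and a step that the two limits leave unreadable from compound 2 to compound 3 cannot be sized. Compound 4 `CCC(CC)C(=O)OCOC(=O)C1=C(S[C@@H]2CN[C@H](C(=O)Nc3cccc(C(=O)O)c3)C2)[C@H](C)[C@@H]2[C@@H]([C@@H](C)O)C(=O)N12` differs from compound 3 by pentan-3-yl in place of ethoxy on a carbonyl carbon. For the measured compounds named here, no measured step bears readably on this change, since all three values are limits. Compound 4 is therefore expected to give 92%, within 75% to 100%. The expected step is a number at least 3 percentage points lower from compound 3 to compound 4 (that floor lies within the scatter).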

Compound 4, percent of the compound remaining: > 95%
Compound 4: no number, only a limit; the forecaster's own chance of this, stated with the estimate: 65%; at least 3 percentage points between middle value and limit.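

For the compounds shown here, no step from compound 1, compound 2 or compound 3 to compound 4 can be read, and the series remains at a single limit: the limit of > 95% in this assay, at which 4 of the 4 values shown sit. The compounds shown leave open whether these four differ at all in this assay.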